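This account rests on a few compounds, and the source may have more. Where it says the series, first, only, none or still open, it means among the compounds named here.

Measured compounds in a toxicity assay on MDCK cells (Canis lupus familiaris) for cytotoxicity, read by crystal violet staining, with a stated time of 48 h; a higher number here means that more compound is tolerated, a lower number that less compound is tolerated:

- compound 1 `Cc1ccc2[nH]c(=O)c(CN(CCCO)Cc3ccc(C(C)(C)C)cc3)cc2c1`: > 10000 nM
- compound 2 `Cc1ccc2[nH]c(=O)c(CN(Cc3ccc(OCC(=O)O)cc3)Cc3ccc(C(C)(C)C)cc3)cc2c1`: > 10000 nM

Both values are limits of this assay, not numbers. For compound 1 the reading of > 10000 nM is a limit. For compound 2 the reading of > 10000 nM is likewise a limit. The step that the two limits leave unreadable from compound 1 to compound 2 cannot be sized because the limit of > 10000 nM in this assay, at which 2 of the 2 values shown sit, leaves no measured number at either end. So compound 2 stands at the limit of this assay, with no numerical position within the shown set.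

Compound 3 `Cc1ccc2[nH]c(=O)c(CN(Cc3ccc(OC(C)C)cc3)Cc3ccc(C(C)(C)C)cc3)cc2c1` is the next member. It differs from compound 2 in one place: isopropyl in place of carboxymethyl on an oxygen on an aromatic ring. Among the compounds with values here, the only measured step that touches this position of the series, from compound 1 to compound 2, is unreadable, so it gives no direction and no size to carry over. Compound 1 and compound 2 both sit at the same limit, and nothing in the shown values distinguishes them.

Compound 3 is therefore expected to remain at or near the same limit, with an estimated value of 15000 nM and a range from 5000 nM to 50000 nM. The implied step that the limit leaves unreadable from compound 2 to compound 3 is expected to be none beyond the scatter, with the reading most likely again a limit rather than a number.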

Compound 3, half-maximal cytotoxic concentration: > 5000 nM
Compound 3: no number, only a limit; the forecaster's own chance of this, stated with the estimate: 70%; the middle value is on the limit's open side.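

In this assay compound 3 reads > 5000 nM, which is a limit and not a number. No new step can be read from compound 3 to compound 1 or compound 2. The compounds shown leave open where any of the three lies beyond its limit, and whether isopropyl in place of carboxymethyl changes the reading at all.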